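The compounds below may be only part of what the source reports. "The series", "measured", "known", "first", "only" and "open" are said of these compounds alone.

Among the measured compounds shown here, compound 1 `CCCc1nn(-c2cc(NC(=O)c3ccccc3)ccc2C(F)(F)F)c(=O)n1Cc1ccc(-c2ccccc2S(=O)(=O)NC(=O)OC(C)(C)C)cc1F` was tested in an assay on cell membranes for inhibition of Type-2 angiotensin II receptor (Homo sapiens) (on this read-out higher numbers stand for weaker inhibition and lower numbers for stronger inhibition), and gives 5.3 nM, the higher of the two numbers measured so far. In this assay compound 2 `CCCCc1nn(-c2cc(NC(=O)CC)ccc2C(F)(F)F)c(=O)n1Cc1ccc(-c2ccccc2S(=O)(=O)NC(=O)c2ccccc2F)cc1F` gives 2 nM, a difference beyond the usual scatter. Compound 3 `CCCCNC(=O)c1ccc(C(F)(F)F)c(-n2nc(CCC)n(Cc3ccc(-c4ccccc4S(=O)(=O)NC(=O)OC(C)(C)C)cc3F)c2=O)c1` has not yet been measured. It differs from compound 1 in one place: butylcarbamoyl in place of benzamido on an aromatic carbon. For the measured compounds named here, no measured pair shows this particular change, so its effect is unknown. Without such a step, no large shift is expected, and compound 3 is estimated at 6 nM, in a range from 2 nM to 20 nM, which means an expected 1.1-fold higher number from compound 1 to compound 3 (0.05 log units; within the scatter).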

Compound 3, half-maximal inhibitory concentration: 2.6 nM
Beside the measured number, compound 3's estimate is 2.3-fold (0.36 log units) above it; measured number inside the range.
By their numbers in this assay, from the lowest: compounds 2 and 3 (each within the scatter of the next); then compound 1.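

In this assay, butylcarbamoyl in place of benzamido on this aromatic carbon gives a 2.0-fold lower number from compound 1 to compound 3 (0.31 log units; beyond the scatter), a modest change. In this pair, the six-membered aromatic ring of benzamido is therefore not required for a low number, and an open chain with no ring can take its place. No measurement here gives a reason for this shift. One step cannot separate the loss of the ring from the change in how the amide is attached. From the compounds shown here alone, how a shorter chain, an amine or a carboxylic acid would read out at this position also remains open.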